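A few compounds are considered here, and "the series" means these few. Any claim that something is new, unique, unknown or untested is made for them only; others in the source may bear on it.

Of the compounds shown here, three of a shared core have been tested in an assay for displacement of a labelled ligand from Sigma non-opioid intracellular receptor 1 (Cavia porcellus), read by scintillation counting, with a stated time of 180 min; on this read-out lower numbers stand for stronger inhibition and higher numbers for weaker inhibition. Compound 3 `CC(C)CCN1CCC2(CC1)OCCc1c2cnn1-c1ccccc1` gives 0.98 nM. Compound 1 `CCCN1CCC2(CC1)OC(OC)Cc1c2cnn1-c1ccccc1` gives 33 nM. Compound 2 `Cn1ncc2c1CC(O)OC21CCN(Cc2ccccc2)CC1` gives 190 nM, the highest number of the three and so the weakest binder here, since its gaps to both compound 1 and compound 3 lie beyond the scatter of the assay. Compound 2 also differs from the other two in carrying a methyl rather than a phenyl on the pyrazole nitrogen and a benzyl rather than a short alkyl chain on the piperidine nitrogen, so no single change links it to either.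

The next compound, compound 4 `Cn1ncc2c1CCOC21CCN(Cc2ccccc2)CC1`, differs from compound 2 in one place: hydrogen in place of hydroxy on a saturated ring carbon, next to the ring oxygen. Going by the values given here, no measured pair shows the effect of this exact change. A small step is expected, toward a lower number rather than a higher one, but it may fall within the scatter. Compound 4 is therefore expected to give about 90 nM in this assay, with a likely range from 25 nM to 320 nM, a step of a 2.1-fold lower number from compound 2 to compound 4 (0.32 log units; beyond the scatter) that is estimated, not measured.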

Compound 4, inhibition constant: 9.2 nM
Compound 4: the middle estimate sits 9.8-fold (0.99 log units) above what was measured, and the stated range ends above it.
By their numbers in this assay, from the lowest: compound 3; then compound 4; then compound 1; then compound 2.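

In this assay, going by these compounds alone, the single change of hydrogen in place of hydroxy gives a 21-fold lower number from compound 2 to compound 4 (1.31 log units; beyond the scatter), a large step beyond the scatter. Within the data shown here, compound 2 and compound 4 differ in this one place, so this pair isolates what the earlier compounds could not: the saturated ring carbon next to the ring oxygen strongly affects the measured binding, and the compound with hydroxy there is the weaker binder of the two. Nothing measured here explains why the binding differs so much between these two compounds.

Still open, from the compounds shown here alone, is how a fluorine, an amine or a methyl on this same carbon would compare with hydrogen and hydroxy. Going by these compounds, it is also open whether the same change would give a step of this size with the other groups carried by compound 3.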